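The source may hold more compounds than are shown below. What is called first, only, known or untested is meant among the compounds shown, and "the series" means these compounds.

Among the measured compounds shown here, compound 3 `Cc1cc(C)cc(SCc2ccc(C(=O)Nc3ccccc3N)cc2)c1` gives the highest of the three numbers so far in a functional assay on HeLa cells (Homo sapiens) for inhibition, read by CCK-8 assay, with a stated time of 72 h, tested at 8 uM (a lower number here means less inhibition of growth, a higher number more inhibition of growth at the concentration tested), at 78.9%. For the measured compounds named here, compound 1 `Nc1ccccc1NC(=O)c1ccc(CSc2cccc(F)c2)cc1` stands within the scatter of it in this assay, at 78.4%, and the step of a number 0.5 percentage points higher from compound 1 to compound 3 (within the scatter) is the only one-place change measured. Compound 2 `CC(C)(C)c1ccc(SCc2ccc(C(=O)Nc3ccccc3N)cc2)cc1`, by contrast, gives only 40.2% in this assay, well below compound 3. Compound 4 `Nc1ccccc1NC(=O)c1ccc(CSc2ccc(Cl)cc2)cc1` differs from compound 3 in one place: 4-chlorophenyl in place of 3,5-dimethylphenyl on a sulfur. The step from compound 1 to compound 3 was within the scatter, so a like swap of the ring substituents would suggest a small step; the low value of compound 2 shows, however, that a single para substituent can sit far lower. The estimate for compound 4 is therefore a modest downward step a number 10.9 percentage points lower from compound 3 to compound 4 (beyond the scatter) in this assay, with the value expected near 68%, between 48% and 85%.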

Compound 4, percent growth inhibition at one concentration: 51.4%
For compound 4 the middle estimate is 16.6 percentage points above the measured one; measured number inside the range.
By their numbers in this assay, from the lowest: compound 2; then compound 4; then compounds 1 and 3 (each within the scatter of the next).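

In this assay, 4-chlorophenyl on the sulfur shows a number 27.5 percentage points lower from compound 3 to compound 4 (beyond the scatter) and a number 27 percentage points lower from compound 1 to compound 4 (beyond the scatter) here, so this change separates it from two groups that lie within the scatter of each other. Chloro in place of tert-butyl on an aromatic carbon gives a number 11.2 percentage points higher from compound 2 to compound 4 (beyond the scatter) and so sets compound 4 apart from the lowest compound as well. Nothing available here accounts for these steps. Going by these compounds, whether 3-chlorophenyl or 4-methoxyphenyl on the sulfur would stand nearer compound 3 or compound 4 remains open.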